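A ring gives way to a chain on nitrogen

A few compounds are considered here, and "the series" means these few. Any claim that something is new, unique, unknown or untested is made for them only; others in the source may bear on it.

Of the compounds shown here, three with a shared core have measured values so far in a functional assay on SK-OV-3 cells (Homo sapiens) for cytotoxicity, read by MTT assay, with a stated time of 3 days (a higher number here means a weaker inhibitor, a lower number a stronger inhibitor), and all lie close together. Compound 1 `N#Cc1c(Cl)nc(SCc2nc3ccccc3[nH]2)nc1-c1ccccc1` bears chloro and gives 3.37 nM as its value. Compound 2 `N#Cc1c(Nc2ccccc2)nc(SCc2nc3ccccc3[nH]2)nc1-c1ccccc1` bears anilino in that place and gives 4.46 nM as its value. Compound 3 `N#Cc1c(Nc2ccccn2)nc(SCc2nc3ccccc3[nH]2)nc1-c1ccccc1` bears (pyridin-2-yl)amino and gives 5.81 nM as its value, within the scatter of both others. Compound 4 `N#Cc1c(NNC(N)=S)nc(SCc2nc3ccccc3[nH]2)nc1-c1ccccc1` is still unmeasured and differs from compound 3 by a group of 4 heavy atoms (1 carbon, 2 nitrogen, 1 sulfur; no ring) in place of a group of 6 heavy atoms (5 carbon, 1 nitrogen; one six-membered aromatic ring with 1 hetero atom), on a nitrogen on an aromatic ring on that same nitrogen.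

The nearest evidence is phenyl giving way to pyridin-2-yl on this nitrogen (a 1.3-fold higher number from compound 2 to compound 3 (0.11 log units; within the scatter)). Replacing chloro by anilino or by (pyridin-2-yl)amino also stayed within the scatter (a 1.3-fold higher number from compound 1 to compound 2 (0.12 log units; within the scatter) and a 1.7-fold higher number from compound 1 to compound 3 (0.24 log units; within the scatter)). None of these groups is an open chain, so this evidence is thin. In this assay no step beyond the scatter is expected, and the estimated size is small (a 1.2-fold lower number from compound 3 to compound 4 (0.07 log units; within the scatter)). For compound 4 the estimated value is 5 nM with a wide expected range (1.5 nM to 20 nM).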

Compound 4, half-maximal inhibitory concentration: 3 nM
Compound 4: middle estimate off by 1.7-fold (0.22 log units), on the high side, and the stated range covers the measured number.
By their numbers in this assay, from the lowest: compounds 4, 1, 2 and 3 (each within the scatter of the next).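

The nitrogen on the shared core takes an open chain as readily as a ring: in this assay, the chain in place of pyridin-2-yl gives (a 1.9-fold lower number from compound 3 to compound 4 (0.29 log units; within the scatter)), and the same chain in place of phenyl gives (a 1.5-fold lower number from compound 2 to compound 4 (0.17 log units; within the scatter)). The whole group in place of chloro on the aromatic carbon also gives a small step (a 1.1-fold lower number from compound 1 to compound 4 (0.05 log units; within the scatter)), so the number stays within the scatter even with a group carrying 2 hydrogen-bond donors and no ring. Nothing measured here explains why these numbers stay so close.

As far as these compounds go, it remains open whether a much smaller group on this nitrogen, such as methyl, would stay within the same range. The same question applies to a longer carbon chain or one ending in a carboxylic acid.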